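Fluoro on the benzyl group of compound 1

A few compounds are considered here, and "the series" means these few. Any claim that something is new, unique, unknown or untested is made for them only; others in the source may bear on it.

Compound 1 `CCN(CCNC(=O)c1cc(Cl)c(N)cc1OC)Cc1ccccc1` gives 0.31 mg/kg in a functional assay on the whole organism with Rattus norvegicus as the target; on this read-out higher numbers stand for an effect only at larger amounts of compound and lower numbers for an effect already at smaller amounts.
Compound 2 `CCNCCNC(=O)c1cc(Cl)c(N)cc1OC` gives only a limit, > 30 mg/kg, in this assay.

Among the compounds with values here, compound 1 holds the only number in this assay; the other value sits at the limit of > 30 mg/kg in this assay, at which 1 of the 2 values shown sits. Compound 3 `CCN(CCNC(=O)c1cc(Cl)c(N)cc1OC)Cc1ccc(F)cc1` differs from compound 1 by fluoro in place of hydrogen on an aromatic carbon. Within the data shown here, the one measured step, an at least 96-fold higher number from compound 1 to compound 2 (1.98 log units; beyond the scatter), concerns the loss of the whole benzyl group and so bears only indirectly on a fluoro added to that group; no measured step touches the benzyl ring itself. A step within the scatter is therefore expected, in no set direction. Compound 3 is expected to give about 0.3 mg/kg in this assay, between 0.12 mg/kg and 0.8 mg/kg. The expected step is a 1.0-fold lower number from compound 1 to compound 3 (0.01 log units; within the scatter).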

Compound 3, dose for half-maximal effect: 0.2 mg/kg
Estimate against measurement, compound 3: 1.5-fold (0.18 log units) above; the measured number falls inside the stated range.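

On the read-out of this assay, the benzyl ring takes fluoro in the place para to a large group, with a 1.6-fold lower number from compound 1 to compound 3 (0.19 log units; within the scatter). The 4-fluorobenzyl group on the amine nitrogen also gives an at least 150-fold lower number from compound 2 to compound 3 (2.17 log units; beyond the scatter), so the size of the step seen with benzyl is matched by a ring-substituted group. This step rests on a limit: the limit of > 30 mg/kg in this assay, at which 1 of the 3 values shown sits.

Open, going by these compounds, is whether chloro, methoxy or trifluoromethyl at this ring place would read the same. Also open, on these data alone, is how a phenethyl chain or a pyridylmethyl group in place of benzyl would read.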